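Chloro to methyl on a highly stable ethylamine

The compounds below may be only part of what the source reports. "The series", "measured", "known", "first", "only" and "open" are said of these compounds alone.

In an ADME assay on microsomes from liver (Homo sapiens) for metabolic stability, read by LC-MS, with a stated time of 30 min, tested at 1 uM (on this read-out lower numbers stand for a less stable compound and higher numbers for a more stable compound), compound 1 `CC(C)(C)NCc1cc(Cl)cc(Nc2nc3cc(F)c(F)cc3n2Cc2ccc(C(F)(F)F)cc2)c1O` gives 89% and compound 2 `Cc1cc(CNC(C)(C)C)c(O)c(Nc2nc3cc(F)c(F)cc3n2Cc2ccc(C(F)(F)F)cc2)c1` gives 90% on this read-out. Compound 3 `CCNCc1cc(Cl)cc(Nc2nc3cc(F)c(F)cc3n2Cc2ccc(C(F)(F)F)cc2)c1O` gives > 99% as a limit of the assay and not a number. It stands at the limit of > 99% in this assay, at which 1 of the 3 values shown sits, and has no exact figure. Compound 4 `CCNCc1cc(C)cc(Nc2nc3cc(F)c(F)cc3n2Cc2ccc(C(F)(F)F)cc2)c1O` differs from compound 3 by methyl in place of chloro on an aromatic carbon with methyl in place of chloro on an aromatic carbon, para to a hydroxy group. The same exchange with tert-butyl on the amine nitrogen gave a number 1 percentage points higher from compound 1 to compound 2 (within the scatter) and so no step beyond the scatter is expected in either direction. The other measured step gave a number at least 10 percentage points higher from compound 1 to compound 3 (that floor lies within the scatter) at the amine nitrogen and does not involve this carbon. The expected step is a number at least 2 percentage points lower from compound 3 to compound 4 (that floor lies within the scatter) and would stay within the scatter. For compound 4 the expected value is 97% with an estimated range from 88% to 100% on this read-out.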

Compound 4, percent of the compound remaining: 99%
The estimate for compound 4 lay 2 percentage points below the measured number; the measured number falls inside the stated range.
By their numbers in this assay, from the lowest: compounds 1, 2 and 4 (each within the scatter of the next).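

In this assay, ethyl in place of tert-butyl on the amine nitrogen can now be read as a number with methyl on the ring, giving a number 9 percentage points higher from compound 2 to compound 4 (within the scatter): the same change on two cores in this assay, a number at least 10 percentage points higher (that floor lies within the scatter) from compound 1 to compound 3 and a number 9 percentage points higher (within the scatter) from compound 2 to compound 4; the limit leaves it open whether they differ
Compound 3 stands at a limit of the assay, > 99%, and not at a number. The step from chloro to methyl with the ethylamine gives a number no higher from compound 3 to compound 4 (the limit leaves the size open) and its size cannot be read: the same change on two cores in this assay, a number 1 percentage points higher (within the scatter) from compound 1 to compound 2 and a number no higher (the limit leaves the size open) from compound 3 to compound 4; the limit leaves it open whether they differ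
With methyl in place of chloro, compound 4 still gives 99%.

On these data alone, how a fluoro, methoxy or nitrile group para to the hydroxy group would read remains open. So does the effect of a cyclopropyl or isopropyl group on the amine nitrogen.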